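The source may report more compounds than this note shows. Statements on the series, on what has been measured and on what is new or still open speak of the compounds shown alone.

Measured compounds:
Compound 1 `CCOc1cc(NC(=O)C2(NC(=O)c3ccc4c(C5CCCC5)c(-c5ncc(Cl)cn5)n(C)c4c3)CCC2)ccc1/C=C/C(=O)OCOP(=O)(O)O` gives, in an ADME assay on stomach for pharmacokinetics, in simulated gastric fluid (on this read-out lower numbers stand for a shorter-lived compound and higher numbers for a longer-lived compound), compound 1 a value of 1.3 h.
Compound 2 `CCCOC(=O)/C=C/c1ccc(NC(=O)C2(NC(=O)c3ccc4c(C5CCCC5)c(-c5ncc(Cl)cn5)n(C)c4c3)CCC2)cc1OCC` gives in this assay compound 2 a value of 2.23 h.

Compound 2 stands alongside compound 1 on these two numbers: the step of a 1.7-fold higher number from compound 1 to compound 2 (0.23 log units; within the scatter) lies within the scatter, so the two cannot be told apart. Compound 3 `CCOc1cc(NC(=O)C2(NC(=O)c3ccc4c(C5CCCC5)c(-c5ncc(Cl)cn5)n(C)c4c3)CCC2)ccc1/C=C/C(=O)OCc1ccccc1` differs from compound 2 by phenyl in place of ethyl on a saturated chain carbon bound to an oxygen next to a carbonyl group. Among the compounds with values here, only one measured step touches the same place, namely a 1.7-fold higher number from compound 1 to compound 2 (0.23 log units; within the scatter), and it did not move the number beyond the scatter. Nothing measured speaks to a phenyl entering there, so the expectation rests on that single step alone. Compound 3 is therefore expected to give about 2 h in this assay, with a range from 1 h to 4 h. This estimate amounts to a step of a 1.1-fold lower number from compound 2 to compound 3 (0.05 log units; within the scatter), expected to stay within the scatter.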

Compound 3, half-life: 1.83 h
Compound 3: the middle estimate sits 1.1-fold (0.04 log units) above what was measured; the measured number falls inside the stated range.
By their numbers in this assay, from the lowest: compounds 1, 3 and 2 (each within the scatter of the next).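

In this assay, the first ring to enter at this saturated chain carbon leaves the read-out within the scatter (a 1.2-fold lower number from compound 2 to compound 3 (0.09 log units; within the scatter)): going from the propoxycarbonyl ester to the benzyloxycarbonyl ester gives no change that can be told from repeat variation. The phosphorus-bearing group and the phenyl also cannot be told apart (a 1.4-fold higher number from compound 1 to compound 3 (0.15 log units; within the scatter)), so all three compounds now sit within the scatter of one another, whether the group there is an open carbon chain, a phosphorus-bearing chain or a carbon ring. Nothing at hand explains why these groups give such similar half-lives.

As far as these compounds go, whether an amine, a carboxylic acid or a much longer chain at this place would move the half-life beyond the scatter remains open. So does whether any change away from this place, such as replacing the ethoxy group, would do so.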